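The source may report more compounds than this note shows. Statements on the series, on what has been measured and on what is new or still open speak of the compounds shown alone.

The measured compounds:
Compound 1, `O=c1c(C(=S)Nc2ccccc2)coc2cc(Cl)ccc12`: > 100000 nM, a limit of the assay.
Compound 2, `O=c1c(C(=S)Nc2ccccc2)coc2ccccc12`: > 100000 nM, a limit of the assay.

Compound 2 is the starting point here. In a functional assay on HEp-2 cells (Homo sapiens) for inhibition, read by sulforhodamine B assay, with a stated time of 48 h (on this read-out higher numbers stand for weaker inhibition and lower numbers for stronger inhibition), compound 2 gives > 100000 nM, which is a limit of the assay and not a measured number. In this assay compound 1 gives > 100000 nM, likewise a limit. Among the compounds with values here, the only measured step, a step that the two limits leave unreadable from compound 1 to compound 2, cannot be read in size because of the limit of > 100000 nM in this assay, at which 2 of the 2 values shown sit. Compound 3, `O=c1c(C(=S)Nc2ccccc2)coc2ccc(F)cc12`, differs from compound 2 by fluoro in place of hydrogen on an aromatic carbon. No measured step bears directly on this change, and the one step available is itself unreadable, so there is no basis on the numbers shown for expecting a shift in either direction beyond the scatter. Compound 3 is therefore estimated at 100000 nM, within a range from 30000 nM to 300000 nM. The expected step of a number no higher from compound 2 to compound 3 (the limit leaves the size open) is none beyond the scatter, with the result most likely reported again as a limit.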

Compound 3, half-maximal inhibitory concentration: > 100000 nM
Compound 3: only a limit was reported; the forecaster's own chance of this, stated with the estimate: 80%; the middle value lies on the limit itself.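

The size of the step from compound 2 to compound 3 cannot be read, because both results are limits and not numbers: the limit of > 100000 nM in this assay, at which 3 of the 3 values shown sit. The compounds shown leave open how strongly each one inhibits, and whether chloro or fluoro on the shared core changes that.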